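The compounds below may be only part of what the source reports. "The series", "measured", "known", "first", "only" and "open" are said of these compounds alone.

Measured compounds in a functional assay on PC-3 cells (Homo sapiens) for antiproliferative activity, read by MTT assay, with a stated time of 72 h; on this read-out higher numbers stand for weaker inhibition and lower numbers for stronger inhibition:
- compound 1 `C=CC(=O)Nc1cc2c(N3CCc4ccccc43)ncnc2cc1OC` gives 5940 nM
- compound 2 `COc1cc2ncnc(N3CCc4ccccc43)c2cc1NC(=O)C=C(C)C` gives 7840 nM
- compound 3 `C=CC(=O)Nc1cc2c(N3CCc4ccccc43)ncnc2cc1O[C@@H]1CCOC1` gives 2710 nM

Compound 3 stands at the lowest number of the three. Its nearest neighbour is compound 1, separated by the step of a 2.2-fold lower number from compound 1 to compound 3 (0.34 log units; beyond the scatter). Going by the values given here, compound 2 gives the furthest number, higher than that of compound 3 and beyond the scatter, though no single-change step joins those two.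

Compound 4 `CC(C)=CC(=O)Nc1cc2c(N3CCc4ccccc43)ncnc2cc1O[C@@H]1CCOC1` differs from compound 3 in one place: 2-methylprop-1-en-1-yl in place of vinyl on a carbonyl carbon. The same change has been measured once within the series, as a 1.3-fold higher number from compound 1 to compound 2 (0.12 log units; within the scatter), which stayed within the scatter. Among the compounds with values here, no other measured step bears on it. On that basis the change is expected to leave the number roughly where compound 3 sits, with the step of a 1.3-fold higher number from compound 3 to compound 4 (0.11 log units; within the scatter) expected to fall within the scatter rather than beyond it. Compound 4 is therefore estimated at 3500 nM in this assay, with a range from 1800 nM to 7000 nM.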

Compound 4, half-maximal inhibitory concentration: 4620 nM
Beside the measured number, compound 4's estimate is 1.3-fold (0.12 log units) below it, within the range that was stated.
By their numbers in this assay, from the lowest: compounds 3, 4, 1 and 2 (each within the scatter of the next, the first and the last beyond it).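

In this assay, 2-methylprop-1-en-1-yl in place of vinyl on a carbonyl carbon now has a reading on a second core, a 1.7-fold higher number from compound 3 to compound 4 (0.23 log units; within the scatter), so the change stays within the scatter on both cores, and the two readings agree: the same change on two cores in this assay, a 1.3-fold higher number (0.12 log units; within the scatter) from compound 1 to compound 2 and a 1.7-fold higher number (0.23 log units; within the scatter) from compound 3 to compound 4, 1.3-fold (0.11 log units) apart, within the scatter of two such steps. Oxolan-3-yl in place of methyl on an oxygen on an aromatic ring also gains a second reading, a 1.7-fold lower number from compound 2 to compound 4 (0.23 log units; within the scatter), and although this step is within the scatter while the earlier one was beyond it, the two do not differ beyond the scatter: the same change on two cores in this assay, a 2.2-fold lower number (0.34 log units; beyond the scatter) from compound 1 to compound 3 and a 1.7-fold lower number (0.23 log units; within the scatter) from compound 2 to compound 4, 1.3-fold (0.11 log units) apart, within the scatter of two such steps. A step beyond the scatter for that change therefore stands on one pair only, compound 1 and compound 3.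

Open, on these data alone, is whether an ethyl group or a vinyl group carrying a dimethylamino chain on the carbonyl carbon would move the number beyond the scatter. Also open, as far as these compounds go, is what a longer chain ending in an amine would give on the oxygen on the aromatic ring.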